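The source may report more compounds than this note shows. Statements on the series, on what has been measured and on what is new or still open speak of the compounds shown alone.

Measured so far: compound 1, `CCc1ccccc1OS(=O)(=O)c1cccc(NC(=O)NCCCCl)c1`, gives 24000 nM; compound 2, `CCCc1ccccc1OS(=O)(=O)c1cccc(NC(=O)NCCCCl)c1`, gives 15000 nM. For compound 3, `Cc1ccccc1NS(=O)(=O)c1ccc(NC(=O)NCCCCl)cc1`, a functional assay on M21 cells (Homo sapiens) for cytotoxicity, read by sulforhodamine B assay, with a stated time of 48 h (a higher number here means a weaker inhibitor, a lower number a stronger inhibitor), returns only a limit, > 200000 nM, as recorded in the limit of > 200000 nM in this assay, at which 1 of the 3 values shown sits.

Between compound 1 and compound 2 the change is methyl in place of hydrogen on a saturated chain carbon, two bonds along the chain from an aromatic carbon, and in this assay it produced a 1.6-fold lower number from compound 1 to compound 2 (0.20 log units; within the scatter). How the core of compound 3 differs from that of compound 1 is not broken down here. Compound 4, `CCc1ccccc1NS(=O)(=O)c1ccc(NC(=O)NCCCCl)cc1`, is not yet measured; it carries methyl in place of hydrogen on a saturated chain carbon bound to an aromatic carbon, the same kind of change as before, though the place differs: here the carbon is bound to an aromatic carbon, whereas earlier it lay two bonds along the chain from an aromatic carbon. Because the earlier step of a 1.6-fold lower number from compound 1 to compound 2 (0.20 log units; within the scatter) stayed within the scatter, only a small step, a step that the limit leaves unreadable from compound 3 to compound 4, is expected. Compound 4 is therefore estimated at 250000 nM, quite possibly again reported only as a limit.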

Compound 4, half-maximal inhibitory concentration: > 200000 nM
Compound 4 ended at the assay's limit; the forecaster's own chance of this, stated with the estimate: 70%; the middle value does not contradict the limit.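

Compound 3 and compound 4 both rest at a limit in this assay, so no step between them can be read: the limit of > 200000 nM in this assay, at which 2 of the 4 values shown sit.

The compounds shown leave open what methyl in place of hydrogen does on the core of compound 3.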